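The compounds below may be only part of what the source reports. "The series", "measured", "known", "first", "only" and "open" are said of these compounds alone.

Series of diaryl thioureas carrying a trifluoromethyl group on one ring, read in an ADME assay on MDBK cells (Bos taurus) for cytotoxicity, read by MTT assay, with a stated time of 96 h; on this read-out lower numbers stand for higher toxicity in this test and higher numbers for lower toxicity in this test. Compound 1 `FC(F)(F)c1cccc(NC(=S)Nc2cccc(Br)c2)c1` gives 10000 nM. Compound 2 `FC(F)(F)c1cccc(NC(=S)Nc2ccc(Cl)cc2)c1` gives 17000 nM; the step of a 1.7-fold higher number from compound 1 to compound 2 (0.23 log units; within the scatter) stays within the scatter. Compound 3 `O=[N+]([O-])c1ccc(NC(=S)Nc2cccc(C(F)(F)F)c2)cc1` gives 10000 nM, and the step of a 1.7-fold lower number from compound 2 to compound 3 (0.23 log units; within the scatter) likewise stays within the scatter. Compound 3 thus stands level with compound 1 at the digits shown, the two together the lowest of the three numbers, with compound 2 the furthest of the set and still within the scatter.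

Compound 4 `CCCC[C@H]1CC[C@H](c2ccc(NC(=S)Nc3cccc(C(F)(F)F)c3)cc2)CC1` is not yet measured. It differs from compound 3 by 4-butylcyclohexyl in place of nitro on an aromatic carbon. Both measured steps exchanged one small group on the second ring for another and moved nothing beyond the scatter; neither bears closely on the entry of a 4-butylcyclohexyl group, so there is no precedent of this kind in the set. The expectation for compound 4 is therefore a number near the three measured values, with a wide range to allow for the size of the change: 8000 nM between 2500 nM and 25000 nM, which would mean an expected step of a 1.3-fold lower number from compound 3 to compound 4 (0.10 log units; within the scatter).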

Compound 4, half-maximal cytotoxic concentration: 10000 nM
Beside the measured number, compound 4's estimate is 1.3-fold (0.10 log units) below it, and the stated range covers the measured number.
By their numbers in this assay, from the lowest: compounds 1, 3, 4 and 2 (each within the scatter of the next).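

In this assay the aromatic carbon that carries nitro also takes 4-butylcyclohexyl, 10 heavy atoms with one non-aromatic ring in place of 3 heavy atoms, and the step of no change at the digits printed from compound 3 to compound 4 (within the scatter) is all that this exchange brings. Taken from chloro at the same carbon, the step of a 1.7-fold lower number from compound 2 to compound 4 (0.23 log units; within the scatter) shows the same picture, so the read-out at this position has now stayed within the scatter for a large group as well as for the small groups compared earlier. Nothing at hand gives a reason for this result.

Still open, on these data alone, is whether an amine, a carboxylic acid or a hydroxyl at this carbon would stay in the same band. As far as these compounds go, the other stereoisomer of the 4-butylcyclohexyl group and a longer chain on the cyclohexyl ring also remain open.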